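The compounds below may be only part of what the source reports. "The series", "measured", "known", "first", "only" and "open" are said of these compounds alone.

Measured in an ADME assay on the whole organism (plasma, Rattus norvegicus) for protein binding, using cassette dosing, at a dose of 1 mg/kg; a higher number here means a larger unbound share of the compound, a lower number a smaller unbound share:

Compound 1 `Cc1cc(/N=c2\[nH]c(=O)n(C[C@H](C)C(=O)O)c(=O)n2Cc2ccc(Cl)cc2)ccc1OC(C)C` gives 0.02
Compound 2 `C[C@@H](Cn1c(=O)[nH]/c(=N\c2ccc(Oc3ccc(F)cn3)cc2)n(Cc2ccc(Cl)cc2)c1=O)C(=O)O` gives 0.011
Compound 3 `CC(C)Oc1ccc(/N=c2\[nH]c(=O)n(CC(C)(C)C(=O)O)c(=O)n2Cc2ccc(Cl)cc2)cc1Cl` gives 0.003

In this assay, compound 2 at 0.011 lies within the usual scatter of compound 1, and beyond the scatter above compound 3. Compound 4 `C[C@@H](Cn1c(=O)[nH]/c(=N\c2ccc(Oc3ccccn3)cc2)n(Cc2ccc(Cl)cc2)c1=O)C(=O)O` differs from compound 2 at a single place, with hydrogen in place of fluoro on an aromatic carbon. For the measured compounds named here, no measured pair of compounds differs at only one place, so the data offer no direct precedent for this change. The estimated step of a 1.3-fold higher number from compound 2 to compound 4 (0.10 log units; within the scatter) is expected to stay within the scatter, with a slight lean towards a larger unbound share. For compound 4 the expected value is 0.014, with an estimated range from 0.006 to 0.03.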

Compound 4, unbound fraction: 0.01
Estimate against measurement, compound 4: 1.4-fold (0.15 log units) above; low and high end bracket the measured number.
By their numbers in this assay, from the lowest: compound 3; then compounds 4, 2 and 1 (each within the scatter of the next).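

Hydrogen in place of fluoro, 5-fluoropyridin-2-yl to pyridin-2-yl, gives in this assay a 1.1-fold lower number from compound 2 to compound 4 (0.04 log units; within the scatter), so the unbound fraction does not distinguish the two atoms at this place on the ring, two atoms from the ring nitrogen. The earlier compounds shown here differ in more than one place and could not isolate this position. No evidence at hand bears on this result.

The compounds shown leave open whether a methoxy, a nitrile or an amine at this place would stay within the scatter of compound 4. They also leave open what a phenyl in place of the pyridin-2-yl would give.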